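Swapping One Aromatic Group on Compound 3

The source may hold more compounds than are shown below. What is called first, only, known or untested is meant among the compounds shown, and "the series" means these compounds.

- compound 1 `CC(NC(=O)Cn1nnc2ccccc2c1=O)c1ccc(Cl)cc1` in an ADME assay on microsomes from liver (Homo sapiens) for metabolic stability; on this read-out lower numbers stand for slow clearance and higher numbers for fast clearance: < 9.9 mL/min/kg, a limit
- compound 2 `Cc1ccc([C@@H](C)NC(=O)Cn2nnc3ccccc3c2=O)cc1` in this assay: < 9.9 mL/min/kg, a limit
- compound 3 `COc1ccc([C@H](C)NC(=O)Cn2nnc3ccccc3c2=O)cc1` in this assay: 13 mL/min/kg

Within the data shown here, compound 3 holds the only true number in this small set, 13 mL/min/kg. The other two results are not numbers but limits: the limit of < 9.9 mL/min/kg in this assay, at which 2 of the 3 values shown sit.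

Compound 4 `Cc1ccc([C@H](C)NC(=O)Cn2nnc3ccccc3c2=O)nc1` carries 5-methylpyridin-2-yl in place of 4-methoxyphenyl on a saturated chain carbon bound to an amide-type nitrogen and a saturated chain carbon. Among the measured compounds shown here, no measured pair shows this swap, so the expectation starts from compound 3 at 13 mL/min/kg, with no shift beyond the scatter. The expected step is a 1.2-fold lower number from compound 3 to compound 4 (0.07 log units; within the scatter). For compound 4 the estimated clearance is 11 mL/min/kg, with an expected range of 7 mL/min/kg to 22 mL/min/kg.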

Compound 4, clearance: < 9.9 mL/min/kg
Compound 4: no number, only a limit (the forecaster's own chance of this, stated with the estimate: 45%); at least 1.1-fold (0.04 log units) between middle value and limit.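

In this assay, 5-methylpyridin-2-yl can take the place of 4-methoxyphenyl on this saturated chain carbon with no rise in clearance, and the change gives an at least 1.3-fold lower number from compound 3 to compound 4 (0.11 log units; that floor lies within the scatter). Going by these compounds, the value for compound 4 is a limit, not a number, so the true size of this step stays unknown. Compound 4 joins the compounds that give no number: the limit of < 9.9 mL/min/kg in this assay, at which 3 of the 4 values shown sit.

Still open, on these data alone, is how a dimethylamino group in place of the methyl of 5-methylpyridin-2-yl would read in this assay. Also open, as far as these compounds go, is whether the compounds that give only a limit truly differ from one another.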